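This account rests on a few compounds, and the source may have more. Where it says the series, first, only, none or still open, it means among the compounds named here.

Compound 3, drawn as `OC1CCN(CCCCOc2ccccc2/C=C/c2ccccc2)CC1`, carries a 4-hydroxypiperidin-1-yl group on the saturated chain that runs from the aromatic oxygen. In a functional assay on the whole organism with Mus musculus as the target, at a dose of 50 mg/kg by the oral route (a lower number here means less inhibition, a higher number more inhibition at the dose given (going by the name of the read-out)), compound 3 gives 50%, the highest of the three numbers measured. Compound 1, `CN(C)CCCCOc1ccccc1/C=C/c1cccc(Cl)c1`, gives 23.9%, a number beyond the scatter below compound 3, and compound 2, `Cc1ccccc1/C=C/c1ccccc1OCCCCN(C)C`, gives 16.7%, also beyond the scatter below compound 3.

Compound 4, `CC(=O)N1CCN(CCCCOc2ccccc2/C=C/c2ccccc2)CC1`, differs from compound 3 in one place: 4-acetylpiperazin-1-yl in place of 4-hydroxypiperidin-1-yl on a saturated chain carbon, four bonds along the chain from an oxygen on an aromatic ring. Within the data shown here, the only measured step, a number 7.2 percentage points lower from compound 1 to compound 2 (within the scatter), concerns the aryl group on the double-bonded chain carbon and lies within the scatter; it says nothing about the amine end of the chain, which is where compound 4 changes. Among the measured compounds shown here, no measured pair varies that position alone, since compound 1 and compound 2 both carry a dimethylamino group and also differ from compound 3 in the aryl ring. The data therefore give no direct guide to the size or direction of the step to compound 4.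

For compound 4 a step of a number 10 percentage points lower from compound 3 to compound 4 (within the scatter) is expected, placing its inhibition at an estimated 40%, within a range from 15% to 65%.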

Compound 4, a percentage reported as inhibition, in the whole organism at one dose (the size of the read-out at that dose, not a potency): 12.5%
The estimate for compound 4 lay 27.5 percentage points above the measured number, outside the stated range (below it).
By their numbers in this assay, from the lowest: compounds 4, 2 and 1 (each within the scatter of the next, the first and the last beyond it); then compound 3.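

In this assay the exchange of 4-hydroxypiperidin-1-yl for 4-acetylpiperazin-1-yl on a saturated chain carbon, four bonds along the chain from an oxygen on an aromatic ring, gives a number 37.5 percentage points lower from compound 3 to compound 4 (beyond the scatter) and is a large step, whereas the earlier change of aryl group gave a number 7.2 percentage points lower from compound 1 to compound 2 (within the scatter) and stayed within the scatter, so this is the first position here shown to move the read-out. The change is not a single one in its parts: the entering group brings a second hetero atom into the six-membered ring and a double bond outside aromatic rings, and it has no hydrogen-bond donor where the leaving group had one, so this one step cannot separate these features from each other. Nothing at hand bears on why the inhibition falls at this position.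

As far as these compounds go, whether the loss goes with the hydroxyl, the acetyl or the ring itself stays open, and a plain piperidine, a 4-methylpiperazine or a morpholine at this place would be needed to tell these apart. Also open, from the compounds shown here alone, is whether a shorter or longer chain to the amine would shift the result in the same direction.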